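Swapping the azole arm for a fluorinated pyridine

The compounds below may be only part of what the source reports. "The series", "measured", "known", "first", "only" and "open" are said of these compounds alone.

Measured compounds:
- compound 1, `NCCCCCOC[C@H]1O[C@@H](OCCc2c[nH]c3ccccc23)[C@H](OCc2ccccc2)[C@@H](OCc2ccccc2)[C@@H]1OCc1ccncc1`, 570 nM
- compound 2, `NCCCCCOC[C@H]1O[C@@H](OCCc2c[nH]c3ccccc23)[C@H](OCc2ccccc2)[C@@H](OCc2ccccc2)[C@@H]1OCc1c[nH]cn1`, 1040 nM

Both compounds share one core and differ only in the aromatic ring hung from the methoxy arm. In an assay on isolated protein for binding affinity to somatostatin receptor type 4 (Homo sapiens), read by radioligand binding (a lower number here means a stronger inhibitor, a higher number a weaker inhibitor), compound 1 gives 570 nM, and compound 2 gives 1040 nM. Going by the values given here, the one step seen so far, a 1.8-fold higher number from compound 1 to compound 2 (0.26 log units; within the scatter), is small, so compound 2 stands with the higher of the two numbers but not apart from compound 1 beyond the scatter.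

Compound 3, `NCCCCCOC[C@H]1O[C@@H](OCCc2c[nH]c3ccccc23)[C@H](OCc2ccccc2)[C@@H](OCc2ccccc2)[C@@H]1OCc1ccc(F)nc1`, carries the change (6-fluoropyridin-3-yl in place of 1H-imidazol-4-yl on a saturated chain carbon bound to an oxygen on a saturated carbon). This brings back a six-membered ring with one nitrogen, now with a fluorine on it. Among the compounds with values here, the only guide is the step from compound 1 to compound 2, which was within the scatter. The number for compound 3 is therefore expected to land near that of compound 1, an estimated 1.6-fold lower number from compound 2 to compound 3 (0.20 log units; within the scatter), giving an expected value of 650 nM (range 250 nM to 1700 nM).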

Compound 3, inhibition constant in the somatostatin receptor type 4 assay: 680 nM
Estimate against measurement, compound 3: 1.0-fold (0.02 log units) below, within the range that was stated.
By their numbers in the somatostatin receptor type 4 assay, from the lowest: compounds 1, 3 and 2 (each within the scatter of the next).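

In the somatostatin receptor type 4 assay the new ring reads as a 1.5-fold lower number from compound 2 to compound 3 (0.18 log units; within the scatter) and as a 1.2-fold higher number from compound 1 to compound 3 (0.08 log units; within the scatter), so pyridin-4-yl, 1H-imidazol-4-yl and 6-fluoropyridin-3-yl all lie within the scatter of one another at this position. Going by these compounds alone, the earlier pair showed only that two rings could be exchanged here; this pair adds that binding need not follow a second measured property, for the two rings stand far apart in a physicochemical assay for acid dissociation, while their binding numbers do not: the measured acid dissociation constant of compound 2, 7.2, and of compound 3, -0.4, a number 7.60 log units lower (beyond the scatter) In the physicochemical assay compound 2 gives 7.2, and compound 3 gives -0.4.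

The compounds shown carry only aromatic rings containing nitrogen at this place, so what a plain phenyl ring would do there stays open. Also open, on these data alone, is whether a ring bearing an amine or a carboxylic acid would stay within the same scatter in the somatostatin receptor type 4 assay.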